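A few compounds are considered here, and "the series" means these few. Any claim that something is new, unique, unknown or untested is made for them only; others in the source may bear on it.

Compound 1 `CN(C)c1ccc(C(=O)Nc2cccc(NC(=O)COc3ccc4c(c3)CCC(=O)N4)c2)cc1`: in an assay on isolated protein for inhibition of Rho-associated protein kinase 1 (Homo sapiens), read by scintillation counting, radiometric assay and 33P incorporation, with a stated time of 40 min, in the presence of a further agent that is not named here (on this read-out lower numbers stand for stronger inhibition and higher numbers for weaker inhibition), compound 1 gives only a limit, > 10000 nM.
Compound 2 `CCCc1ccc(C(=O)Nc2cccc(NC(=O)COc3ccc4c(=O)ccoc4c3)c2)cc1`: compound 2 gives 143 nM.
Compound 3 `O=C(COc1ccc2c(=O)ccoc2c1)Nc1cccc(NC(=O)c2ccc(F)cc2)c1`: compound 3 gives 129 nM.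

Compound 3 and compound 2 sit within the scatter of each other, and compound 1 reports a limit rather than a number. Compound 4 `COC(=O)c1ccc(C(=O)Nc2cccc(NC(=O)COc3ccc4c(=O)ccoc4c3)c2)cc1` differs from compound 3 by methoxycarbonyl in place of fluoro on an aromatic carbon. Among the compounds with values here, the one measured step at this position, a 1.1-fold lower number from compound 2 to compound 3 (0.04 log units; within the scatter), showed that swapping one group for another on this aromatic carbon left the number essentially unchanged. Within the data shown here, only that single step bears on the new change, so for compound 4 no step beyond the scatter is expected in either direction, a 1.2-fold higher number from compound 3 to compound 4 (0.07 log units; within the scatter). Compound 4 is therefore estimated at 150 nM, with a plausible range from 50 nM to 500 nM.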

Compound 4, half-maximal inhibitory concentration: 72 nM
Estimate against measurement, compound 4: 2.1-fold (0.32 log units) above; low and high end bracket the measured number.
By their numbers in this assay, from the lowest: compounds 4, 3 and 2 (each within the scatter of the next). At a limit, above all of these: compound 1.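

The aromatic carbon para to a large group now holds three different groups with no step beyond the scatter: methoxycarbonyl, which brings 4 heavy atoms and 2 hydrogen-bond acceptors, reads as a 1.8-fold lower number from compound 3 to compound 4 (0.25 log units; within the scatter) against fluoro and a 2.0-fold lower number from compound 2 to compound 4 (0.30 log units; within the scatter) against propyl. So even this larger group, with its carbonyl, does not separate from the smaller fluoro or the propyl chain.

Nothing given here accounts for how closely these three groups agree. Going by these compounds, whether an amine, a carboxylic acid or a longer chain at this carbon would also stay within the scatter remains open.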